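Changing the aryl group on the shared core

The compounds below may be only part of what the source reports. "The series", "measured", "known", "first", "only" and "open" are said of these compounds alone.

Measured compounds:
compound 1 `CCc1ccc(Nc2cc(NC(=O)Nc3c(Cl)cccc3Cl)ncn2)cc1`: 70.1%
compound 2 `Cc1ccc(Nc2cc(NC(=O)Nc3c(Cl)cccc3Cl)ncn2)cc1F`: 92%
compound 3 `O=C(Nc1cc(Nc2ccc(F)c(Cl)c2)ncn1)Nc1c(Cl)cccc1Cl`: 91.1%

All three share one core and differ only in the aryl group on a nitrogen on an aromatic ring. In a functional assay on PC-9 cells (Homo sapiens) for inhibition, read by MTT assay, with a stated time of 48 h, tested at 10 uM (a lower number here means less inhibition, a higher number more inhibition at the concentration tested (going by the name of the read-out)), compound 3 stands second highest of the three: compound 2 is nearest, within the scatter, while compound 1 lies furthest, as a number 21 percentage points higher from compound 1 to compound 3 (beyond the scatter) shows. Compound 4 `Cc1cc(F)cc(Nc2cc(NC(=O)Nc3c(Cl)cccc3Cl)ncn2)c1` is not yet measured; it differs from compound 3 by 3-fluoro-5-methylphenyl in place of 3-chloro-4-fluorophenyl on a nitrogen on an aromatic ring. The relevant steps are a number 21.9 percentage points higher from compound 1 to compound 2 (beyond the scatter) and a number 21 percentage points higher from compound 1 to compound 3 (beyond the scatter), both modest gains when 4-ethylphenyl gives way to a doubly substituted phenyl, and a number 0.9 percentage points lower from compound 2 to compound 3 (within the scatter), which stays within the scatter. Since compound 4 keeps a doubly substituted phenyl, the step is expected to stay within the scatter (a number 5.1 percentage points lower from compound 3 to compound 4 (within the scatter)). Compound 4 is therefore expected to give 86%, between 68% and 96%.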

Compound 4, a percentage reported as inhibition, at one concentration (the size of the read-out at that concentration, not a potency): 80%
Compound 4: middle estimate off by 6 percentage points, on the high side; the measured number falls inside the stated range.
By their numbers in this assay, from the lowest: compounds 1 and 4 (each within the scatter of the next); then compounds 3 and 2 (each within the scatter of the next).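

In this assay, two phenyl groups that each carry two substituents are not interchangeable on this nitrogen: 3-fluoro-5-methylphenyl gives a number 11.1 percentage points lower from compound 3 to compound 4 (beyond the scatter) and a number 12 percentage points lower from compound 2 to compound 4 (beyond the scatter) even though it has the same heavy-atom count as 3-chloro-4-fluorophenyl. Its step from 4-ethylphenyl, a number 9.9 percentage points higher from compound 1 to compound 4 (within the scatter), shows no gain that clears the scatter, so having two substituents does not by itself secure the gain seen with compounds 2 and 3. No measurement here explains these differences. Still open, going by these compounds, is how this position would respond to a phenyl bearing an amine or a carboxylic acid, or to a chain longer than ethyl.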